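A few compounds are considered here, and "the series" means these few. Any claim that something is new, unique, unknown or untested is made for them only; others in the source may bear on it.

Measured in a functional assay on A-375 cells (Homo sapiens) for inhibition, read by MTT assay, with a stated time of 48 h; a lower number here means a stronger inhibitor, a higher number a weaker inhibitor:
Compound 1 `COc1ccc(CO[C@H]2C=C[C@H]3C/C=C\C[C@H](c4ccc(F)cc4)OC(=O)C[C@@H]2O3)cc1`: 4760 nM
Compound 2 `COc1ccc(CO[C@H]2C=C[C@H]3C/C=C\C[C@H](c4ccc5ccccc5c4)OC(=O)C[C@@H]2O3)cc1`: > 100000 nM

Compound 2 stands at the limit of > 100000 nM in this assay, at which 1 of the 2 values shown sits. This is a limit of the assay and not a number.

Compound 3 `O=C1C[C@@H]2O[C@@H](C=C[C@@H]2O)C/C=C\C[C@H](c2ccc3ccccc3c2)O1` differs from compound 2 in one place: hydrogen in place of 4-methoxybenzyl on an oxygen on a saturated carbon. In other words, (4-methoxybenzyl)oxy becomes hydroxy, while the naphthalen-2-yl group stays.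

Among the measured compounds shown here, the only measured step is an at least 21-fold higher number from compound 1 to compound 2 (1.32 log units; beyond the scatter). That step lies elsewhere in the molecule, so it does not size this change directly. It shows only that one substitution on the shared core can have a large effect in this assay. A sizeable move toward a lower number is therefore expected, although compound 3 may also remain at the limit. The expected change is an at least 3.3-fold lower number from compound 2 to compound 3 (0.52 log units; beyond the scatter). For compound 3 the estimated value is 30000 nM, with an expected range of 6000 nM to 100000 nM.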

Compound 3, half-maximal inhibitory concentration: 50000 nM
The estimate for compound 3 lay 1.7-fold (0.22 log units) below the measured number; the measured number falls inside the stated range.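

Compound 2 sits at a limit of the assay, which is not a number: the limit of > 100000 nM in this assay, at which 1 of the 3 values shown sits. With 4-methoxybenzyl replaced by hydrogen on this oxygen, compound 3 gives a measurable 50000 nM in this assay, the first reading on the scale for a naphthalen-2-yl compound and the first change shown at this oxygen rather than at the saturated ring carbon (an at least 2.0-fold lower number from compound 2 to compound 3 (0.30 log units; that floor lies within the scatter)). The printed floor of that step lies within the scatter, so the result places compound 3 on the scale but does not establish the true size of the change.

The compounds shown leave open how the same change reads with 4-fluorophenyl on the shared core. They also leave open what a methyl ether, an acetate ester or an amine would give at this position.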